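The compounds below may be only part of what the source reports. "The series", "measured", "known", "first", "only" and "open" are said of these compounds alone.

Measured so far, in a functional assay on MOLT-4 cells (Homo sapiens) for inhibition; a lower number here means a stronger inhibitor, a higher number a weaker inhibitor:
compound 1 `CC(C)C(NC(=O)NO)C(=O)NC1CCCC1` gives > 200000 nM
compound 2 `CC(C)C(NC(=O)n1nnc2ccccc21)C(=O)NC1CCCC1` gives > 200000 nM
compound 3 `CCC(C)C(NC(=O)n1nnc2ccccc21)C(=O)NC1CCCC1` gives 94000 nM

The values for compound 1 and compound 2 are limits of this assay, not numbers; compound 1 reaches only the limit (the limit of > 200000 nM in this assay, at which 2 of the 3 values shown sit). Compound 3 differs from compound 2 by methyl in place of hydrogen on a saturated chain carbon, three bonds along the chain from an amide-type nitrogen and a carbonyl carbon, and this gave an at least 2.1-fold lower number from compound 2 to compound 3 (0.32 log units; beyond the scatter). How the core of compound 1 differs from that of compound 2 is not broken down here. Compound 4 `CCC(C)C(NC(=O)NO)C(=O)NC1CCCC1` differs from compound 1 by methyl in place of hydrogen on a saturated chain carbon, three bonds along the chain from an amide-type nitrogen and a carbonyl carbon, the same change made from compound 2 to compound 3. Because compound 1 sits at the limit of > 200000 nM in this assay, at which 2 of the 3 values shown sit, and the earlier step was only an at least 2.1-fold lower number from compound 2 to compound 3 (0.32 log units; beyond the scatter), compound 4 is expected to show at most a small step, estimated as a number no higher from compound 1 to compound 4 (the limit leaves the size open). Compound 4 is estimated at 200000 nM, between 80000 nM and 600000 nM, with a real chance that only a limit is reported.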

Compound 4, half-maximal inhibitory concentration: > 100000 nM
Compound 4 gave a limit, no number; the forecaster's own chance of this, stated with the estimate: 60%; the middle value does not contradict the limit.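

Compound 1 and compound 4 both gave only limits of the assay, not numbers, so the step between them cannot be read. The compounds shown leave open whether methyl in place of hydrogen changes the number on the core of compound 1.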